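Propanoyl for Ethyl on a Ring Nitrogen

This account rests on a few compounds, and the source may have more. Where it says the series, first, only, none or still open, it means among the compounds named here.

Compound 2 `CCN1CC2(CC(NC(=O)c3cc(-c4ccccc4)no3)C2)C1` carries an ethyl group on an amine nitrogen in a ring. In an ADME assay on microsomes from liver (Homo sapiens) for metabolic stability, with a stated time of 0.5 h, tested at 0.5 mg/mL (a higher number here means that more of the compound is left, a lower number that less of the compound is left), compound 2 gives 100%. Of the two plain numbers shown, this is the higher one; the nearest is compound 3 `CC(CC(=O)N(C)C)NC(=O)c1cc(-c2ccc(F)cc2)no1`, which in this assay gives 91%, a gap that lies within the usual scatter. Compound 1 `CC(=O)N1CC2(CC(NC(=O)c3cc(-c4ccccc4)no3)C2)C1` gives only a limit of the assay in this assay, namely > 100%.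

Going by the values given here, the single measured step between neighbours, a number no higher from compound 1 to compound 2 (the limit leaves the size open), swaps an acetyl for an ethyl on that nitrogen and arrives at a number no higher than its starting point, its size left open because the starting point is a limit (the limit of > 100% in this assay, at which 1 of the 3 values shown sits).

Compound 4 `CCC(=O)N1CC2(CC(NC(=O)c3cc(-c4ccccc4)no3)C2)C1` differs from compound 2 by propanoyl in place of ethyl on an amine nitrogen in a ring. This is the measured step run backwards with one carbon more, so no fall is expected, and the value may again reach the limit. Compound 4 is therefore expected to give 100%, between 88% and 100%. The expected step of no change at the digits printed from compound 2 to compound 4 (within the scatter) stays within the scatter.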

Compound 4, percent of the compound remaining: 68%
Compound 4: middle estimate off by 32 percentage points, on the high side, and the stated range ends above it.
By their numbers in this assay, from the lowest: compound 4; then compounds 3 and 2 (each within the scatter of the next).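

In this assay, going by these compounds alone, this ring nitrogen proves sensitive to small edits: propanoyl in place of ethyl gives a number 32 percentage points lower from compound 2 to compound 4 (beyond the scatter), a drop of which the earlier compounds gave no sign. Lengthening the acyl group by a single carbon also matters, as methyl in place of hydrogen on a saturated chain carbon bound to a carbonyl carbon gives a number at least 32 percentage points lower from compound 1 to compound 4 (beyond the scatter). That size is only a floor, since compound 1 gives a limit of the assay rather than a number: the limit of > 100% in this assay, at which 1 of the 4 values shown sits.

These compounds do not show why one extra carbon has so large an effect, or which part of compound 4 is lost in the assay. Also open, as far as these compounds go, is whether a longer chain such as butanoyl on the same nitrogen would give a still lower number, or whether a methyl group on that nitrogen would behave like the ethyl group.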